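One flipped stereocentre and its expected effect

This account rests on a few compounds, and the source may have more. Where it says the series, first, only, none or still open, it means among the compounds named here.

Measured in a physicochemical assay for solubility, in phosphate buffer, measured as kinetic solubility (a lower number here means a less soluble compound, a higher number a more soluble compound), so far
Compound 1 `Cc1cc(C(/C=C2\OC(=O)NC2=O)C(C)C)c(=O)[nH]c1-c1ccc2cccc(F)c2c1` gives 35700 nM
Compound 2 `CC(C)[C@@H](c1ccc(-c2ccc3cccc(F)c3c2)[nH]c1=O)[C@@H]1OC(=O)NC1=O` gives 27400 nM

Compound 2 at 27400 nM and compound 1 at 35700 nM lie within the usual scatter of each other, so neither stands apart on these numbers.

Compound 3 `CC(C)[C@@H](c1ccc(-c2ccc3cccc(F)c3c2)[nH]c1=O)[C@H]1OC(=O)NC1=O` awaits measurement in this assay and differs from compound 2 only in its drawn configuration. The difference is the two compounds have the same atoms and bonds and differ only in configuration as drawn: 1 of 2 stereo elements differ; a stereocentre at a saturated ring carbon is drawn S in compound 2 and R in compound 3 and it lies at a stereocentre at a saturated ring carbon, drawn S in compound 2 and R in compound 3.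

Among the measured compounds shown here, no measured pair here shows what such a change does. The expectation therefore rests on compound 2 at 27400 nM and foresees no step beyond the scatter in this assay in either direction. The estimated change is a 1.0-fold higher number from compound 2 to compound 3 (0.01 log units; within the scatter) and it stays within the scatter. For compound 3 the expected value is 28000 nM with an estimated range from 13000 nM to 58000 nM in repeat measurements.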

Compound 3, solubility: 31600 nM
For compound 3 the middle estimate is 1.1-fold (0.05 log units) below the measured one, within the range that was stated.
By their numbers in this assay, from the lowest: compounds 2, 3 and 1 (each within the scatter of the next).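

In this assay, among the compounds shown here, this pair gives the first direct reading of what swapping the drawn configuration at the saturated ring carbon does: a 1.2-fold higher number from compound 2 to compound 3 (0.06 log units; within the scatter). For the compounds shown here, on this read-out, therefore, the S and R forms at this stereocentre cannot be told apart, a point that the earlier compounds, which formed no such single-change pair, could not settle. The comparison is a clean one, since a single feature separates the two structures: the fact that compounds 2 and 3 differ only in the configuration as drawn.

From the compounds shown here alone, the second stereocentre is drawn the same way in compound 2 and compound 3, so the effect of inverting it remains open. Also open, going by these compounds, is whether the ring carbon's configuration would still make so little measurable difference with another group, such as an amine or a carboxylic acid, attached to the shared core.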